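A Second Fluorine on the Arylsulfonamide

A few compounds are considered here, and "the series" means these few. Any claim that something is new, unique, unknown or untested is made for them only; others in the source may bear on it.

Compound 1 `COc1ncc(-c2ccc3ncnc(NCCN(C)C)c3c2)cc1NS(C)(=O)=O` gives 13500 nM in a functional assay on HCT-116 cells (Homo sapiens) for antiproliferative activity, read by sulforhodamine B assay, with a stated time of 72 h; on this read-out higher numbers stand for weaker inhibition and lower numbers for stronger inhibition. For the measured compounds named here, compound 2 `COc1ncc(-c2ccc3ncnc(NCCN(C)C)c3c2)cc1NS(=O)(=O)c1ccc(F)cc1` gives 3200 nM in this assay, the lowest of the two numbers so far; the single measured step, a 4.2-fold lower number from compound 1 to compound 2 (0.63 log units; beyond the scatter), is the only comparison at hand. Compound 3 `COc1ncc(-c2ccc3ncnc(NCCN(C)C)c3c2)cc1NS(=O)(=O)c1ccc(F)cc1F` differs from compound 2 by fluoro in place of hydrogen on an aromatic carbon. Going by the values given here, that earlier step exchanged methyl for 4-fluorophenyl on a sulfonyl sulfur, whereas here one hydrogen becomes fluoro, so no measured step bears directly on it and a shift within the scatter is expected. For compound 3 the estimate is 2500 nM, between 1000 nM and 7000 nM, an expected step of a 1.3-fold lower number from compound 2 to compound 3 (0.11 log units; within the scatter).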

Compound 3, half-maximal inhibitory concentration: 1440 nM
For compound 3 the middle estimate is 1.7-fold (0.24 log units) above the measured one; low and high end bracket the measured number.
By their numbers in this assay, from the lowest: compound 3; then compound 2; then compound 1.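

In this assay, for the compounds shown here, fluoro in place of hydrogen on an aromatic carbon ortho to a large group gives a 2.2-fold lower number from compound 2 to compound 3 (0.35 log units; beyond the scatter), so this position responds to a single added atom, which the earlier compounds could not show. Measured against the methyl sulfonamide, the 2,4-difluorophenyl group gives a 9.4-fold lower number from compound 1 to compound 3 (0.97 log units; beyond the scatter). No evidence is at hand to explain this gain. Open, from the compounds shown here alone, is whether chloro or an amine on the same carbon would give a similar step, and whether fluoro elsewhere on this ring would match it.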